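The compounds below may be only part of what the source reports. "The series", "measured", "known", "first", "only" and "open" are said of these compounds alone.

Measured compounds:
compound 1 `Oc1c(C(c2ccc(F)cc2)N2CCCCC2)ccc2c1OCCO2`: 290 nM
compound 2 `Cc1ccnc(NC(c2cc(C)ccc2C)c2ccc3cccnc3c2O)c1`: > 40000 nM
compound 3 `Oc1ccc2[nH]ncc2c1C(c1ccc(F)cc1)N1CCCCC1`: 350 nM

In an assay for inhibition of protein disulfide-isomerase (Homo sapiens), with a stated time of 1 h (on this read-out lower numbers stand for stronger inhibition and higher numbers for weaker inhibition), compound 1 gives 290 nM. Compound 3 gives 350 nM in this assay, and compound 3 and compound 1 stand within the scatter of each other, so no order between them can be read from these two numbers. For compound 2 the assay reports only a limit, > 40000 nM, and the limit of > 40000 nM in this assay, at which 1 of the 3 values shown sits, is where that value sits.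

Compound 4 `Oc1ccc2[nH]ncc2c1C(c1ccc(-c2nccs2)cc1)N1CCCCC1` is the unmeasured partner of compound 3, differing by 1,3-thiazol-2-yl in place of fluoro on an aromatic carbon. Going by the values given here, no pair of measured compounds shows a step of this kind, so the expectation for compound 4 rests on the value of compound 3 alone. The step from compound 3 to compound 4 is expected to be small in this assay, most likely not beyond the scatter, as a 1.4-fold lower number from compound 3 to compound 4 (0.15 log units; within the scatter). Compound 4 is therefore estimated at 250 nM, with a range from 60 nM to 1200 nM.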

Compound 4, half-maximal inhibitory concentration: 340 nM
Compound 4: middle estimate off by 1.4-fold (0.13 log units), on the low side; the range from low to high includes it.
By their numbers in this assay, from the lowest: compounds 1, 4 and 3 (each within the scatter of the next). At a limit, above all of these: compound 2.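

Going by these compounds alone, the step at this aromatic carbon, a 1.0-fold lower number from compound 3 to compound 4 (0.01 log units; within the scatter), gives the first reading of a change at this position in this assay. Compound 3 and compound 4 cannot be told apart, so the position carries either a single fluorine or a five-membered aromatic ring of 5 heavy atoms with no difference that can be read. Nothing measured here gives a reason for this.

Still open, as far as these compounds go, is whether an amine or a carboxylic acid on this carbon would also stay within the scatter. The same holds for 1,3-thiazol-2-yl on the core of compound 1.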